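The compounds below may be only part of what the source reports. "The series", "measured", "known", "first", "only" and "open" are said of these compounds alone.

Compound 1 `Cc1c(Nc2ccc(S(C)(=O)=O)cc2F)ncnc1O[C@H]1CC[C@]2(CC1)COC(C)(C)C2` is tested in a functional assay on HEK293 cells with Glucose-dependent insulinotropic receptor (Homo sapiens) as the target, read by HTRF and cAMP accumulation, with a stated time of 30 min (on this read-out lower numbers stand for smaller maximal responses and higher numbers for larger maximal responses), and gives 91%. Among the three measured compounds this is the lowest number, but only by margins that fall within the usual scatter: compound 3 `Cc1c(Nc2ccc(S(C)(=O)=O)cc2)ncnc1O[C@H]1CC[C@]2(CC1)COC(C)(C)C2` gives 92%, a step of a number 1 percentage points higher from compound 1 to compound 3 (within the scatter), and compound 2 `Cc1c(Nc2ccc(C(=O)N(C)C)cc2F)ncnc1O[C@H]1CC[C@]2(CC1)COC(C)(C)C2` gives 101%, a step of a number 10 percentage points higher from compound 1 to compound 2 (within the scatter). Neither change on the aromatic ring therefore moves the maximal response noticeably.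

Compound 4 `Cc1c(O[C@H]2CC[C@]3(CC2)COC(C)(C)C3)ncnc1N(C)c1ccc(S(C)(=O)=O)cc1F` is not yet measured. It differs from compound 1 by methyl in place of hydrogen on a nitrogen on an aromatic ring. Both measured steps alter a group on the aromatic carbon, not the nitrogen, so no step of this kind exists among the numbers shown; they only indicate that small edits at this end of the molecule left the maximal response unchanged. The expectation for compound 4 is therefore a step of a number 6 percentage points lower from compound 1 to compound 4 (within the scatter), with a wide range because nothing measured speaks directly to this nitrogen. The estimated maximal response of compound 4 in this assay is 85%, between 50% and 105%.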

Compound 4, intrinsic activity: the largest response reached, in percent of the reference agonist's: 17%
For compound 4 the middle estimate is 68 percentage points above the measured one; the whole stated range lies above it.
By their numbers in this assay, from the lowest: compound 4; then compounds 1, 3 and 2 (each within the scatter of the next).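

Unlike the two edits on the aromatic carbon, which stayed within the scatter, methyl in place of hydrogen on this nitrogen gives a number 74 percentage points lower from compound 1 to compound 4 (beyond the scatter) in this assay. The maximal response therefore depends strongly on what this nitrogen carries, even though the entering methyl adds only 1 heavy atom. Nothing available here bears on the reason for this drop.

Going by these compounds, it remains open whether any group on this nitrogen lowers the maximal response this far, or whether a longer chain such as ethyl, or an acetyl group, would behave differently from methyl. On these data alone, it is also open whether the same methyl has a similar effect in compound 2 and compound 3, which carry different groups on the aromatic ring.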